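The source may hold more compounds than are shown below. What is called first, only, known or untested is meant among the compounds shown, and "the series" means these compounds.

All values are from a functional assay on MCF7 cells (Homo sapiens) for cytotoxicity, read by MTT assay, with a stated time of 4 days; a lower number here means a stronger inhibitor, a higher number a weaker inhibitor.

Compound 1 `C=C1C[C@]23C[C@@]1(O)CC[C@H]2c1cc(Br)c(O)c(C)c1[C@@H]3Cn1cc(-c2ccc(OC)cc2)nn1` gives > 20000 nM, which is a limit of the assay and not a number.
Compound 2 `C=C1C[C@]23C[C@@]1(O)CC[C@H]2c1ccc(OS(=O)(=O)c2ccc(C)cc2)c(C)c1[C@@H]3Cn1cc(-c2ccc(C)cc2)nn1` gives > 20000 nM, again a limit.
Compound 3 `C=C1C[C@]23C[C@@]1(O)CC[C@@H]2c1cccc(C)c1[C@@H]3Cn1cc(-c2ccc(Cl)cc2)nn1` gives > 20000 nM, again a limit.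

Where compound 3 stands: it sits at the limit of this assay, and it is not alone there, since (the limit of > 20000 nM in this assay, at which 3 of the 3 values shown sit). Among the measured compounds shown here, no compound of the series has a numerical value, so no measured step between two compounds exists, and nothing can be said about how any single change moves the read-out in this assay.

The next compound is compound 4 `C=C1C[C@]23C[C@@]1(O)CC[C@@H]2c1cccc(C)c1[C@@H]3Cn1cc(-c2ccc(C)cc2)nn1`. It differs from compound 3 in one place: methyl in place of chloro on an aromatic carbon. Compound 2 carries the same 4-methylphenyl group as compound 4, on a core that differs elsewhere, and compound 2 also sits at the limit.

Expectation: the change from compound 3 to compound 4 is expected to give no step beyond the scatter in this assay, the estimated step being a step that the limit leaves unreadable from compound 3 to compound 4. Compound 4 is therefore expected to come out at 30000 nM, with a range from 12000 nM to 90000 nM, and most likely to be reported only as a limit, as the three measured compounds are.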

Compound 4, half-maximal inhibitory concentration: > 20000 nM
Compound 4: only a limit was reported; the forecaster's own chance of this, stated with the estimate: 85%; the middle value is on the limit's open side.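

In this assay compound 4 gives > 20000 nM, a limit and not a number. Among the compounds shown here, with compound 3 also at a limit, no step from compound 3 to compound 4 can be read. The series stays at one limit: the limit of > 20000 nM in this assay, at which 4 of the 4 values shown sit.

The compounds shown leave open whether any change to this series gives a numerical value in this assay.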